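A Methyl on the Amide Nitrogen of Compound 2

The source may report more compounds than this note shows. Statements on the series, on what has been measured and on what is new or still open speak of the compounds shown alone.

Three measured compounds here share a core carrying an ethenyl chain that ends in a carbonyl group, and all were tested in a functional assay on A549 cells (Homo sapiens) for inhibition, read by sulforhodamine B assay, with a stated time of 72 h; on this read-out higher numbers stand for weaker inhibition of growth and lower numbers for stronger inhibition of growth. Compound 1 `CCOC(=O)/C=C/c1ccncc1-c1ccc2[nH]ccc2c1` gives 7440 nM in this assay. Compound 3 `Cn1ccc2cc(-c3cnccc3/C=C/C(=O)O)ccc21` returns only a limit of this assay, > 10000 nM. Compound 2 `NC(=O)/C=C/c1ccncc1-c1ccc2ccccc2c1` likewise returns only a limit, > 10000 nM, so no number stands for it. Two of the three values shown sit at this boundary (the limit of > 10000 nM in this assay, at which 2 of the 3 values shown sit), and compound 2 is one of them; compound 1 alone gives a number inside the working range of this assay.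

Compound 4 `CNC(=O)/C=C/c1ccncc1-c1ccc2ccccc2c1` has not yet been measured. It differs from compound 2 in one place: methyl in place of hydrogen on an amide-type nitrogen. The hydrogen on the amide-type nitrogen, whose other neighbour is a carbonyl carbon, gives way to a methyl, turning a carbamoyl into a methylcarbamoyl.

Among the measured compounds shown here, no step between two measured compounds is available, so the effect of this change has no direct precedent here. Since compound 2 sits at a limit, the step that the limit leaves unreadable from compound 2 to compound 4 is expected to be small, within the usual scatter. Compound 4 is therefore expected at about 12000 nM, between 5000 nM and 30000 nM, with a real chance that this assay again reports only a limit.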

Compound 4, concentration for 50% growth inhibition: 6620 nM
For compound 4 the middle estimate is 1.8-fold (0.26 log units) above the measured one; measured number inside the range.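

Compound 4 gives a real number in this assay, 6620 nM, and among the compounds shown it is the first amide on this ethenyl chain to do so. For compound 2, the value of > 10000 nM is a limit of the assay and not a number. Placing a methyl on the amide nitrogen therefore goes with an at least 1.5-fold lower number from compound 2 to compound 4 (0.17 log units; that floor lies within the scatter), which means that even this smallest possible change may matter at this position, although the printed floor alone does not establish a real gain, and the full size of the step stays hidden because compound 2 has no number of its own: the limit of > 10000 nM in this assay, at which 2 of the 4 values shown sit.

The compounds shown leave open whether a second methyl on the same nitrogen, an ethyl or a longer chain there, or a ring such as cyclopropyl would carry the number further down, or whether the single methyl is as far as this position goes. Compound 1 and compound 3 differ from compound 4 in more than one place, so they cannot settle this question.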